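A few compounds are considered here, and "the series" means these few. Any claim that something is new, unique, unknown or untested is made for them only; others in the source may bear on it.

Measured so far:
compound 1 `C#CCn1cc(C(=O)NC(CC(=O)Nc2ccccc2)c2ccccc2)c(=O)c2cc(F)c(Cl)nc21` — 5700 nM
compound 2 `C#CCn1cc(C(=O)NC(CC(=O)Nc2ccccn2)c2ccccc2)c(=O)c2ccc(Cl)nc21` — 2900 nM

In a functional assay on SW-620 cells (Homo sapiens) for cytotoxicity, read by MTT assay, with a stated time of 72 h (a lower number here means a stronger inhibitor, a higher number a weaker inhibitor), compound 1 gives 5700 nM, the higher of the two numbers in hand. Its nearest neighbour is compound 2, which in this assay gives 2900 nM; the gap between these two lies within the scatter, so the two compounds are read as equivalent and no order is drawn from them. The two differ in more than one place, and nothing is taken from that pair beyond the two values themselves.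

Compound 3 `C#CCn1cc(C(=O)NC(CC(=O)NC2CCCCC2)c2ccccc2)c(=O)c2cc(F)c(Cl)nc21` keeps the core of compound 1 and differs from it in one place: cyclohexyl in place of phenyl on an amide-type nitrogen. For the measured compounds named here, no pair of measured compounds shows this change, so there is no measured step to lean on. With the cyclohexyl carrying the same counts as the phenyl it replaces, the expectation is a step of no size beyond the scatter, in no preferred direction, and a wide range is kept to reflect the missing precedent.

Compound 3 is therefore expected in this assay to give 5000 nM, with a range from 1800 nM to 14000 nM. The change this estimate implies is a 1.1-fold lower number from compound 1 to compound 3 (0.06 log units; within the scatter).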

Compound 3, half-maximal inhibitory concentration: > 10000 nM
Compound 3: no number, only a limit; the forecaster's own chance of this, stated with the estimate: 5%; middle value at least 2.0-fold (0.30 log units) away from the limit.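

In this assay compound 3 gives > 10000 nM, which is a limit of the assay and not a number. For the compounds shown here, the exchange of a six-membered aromatic ring of carbon only for a six-membered non-aromatic ring of carbon only, on an amide-type nitrogen and with the heavy-atom count unchanged, is the first single-place change and reads as an at least 1.7-fold higher number from compound 1 to compound 3 (0.24 log units; that floor lies within the scatter), so cyclohexyl gives no sign of a lower number at this place, although that floor alone does not separate the two groups. The true size of the step stays unknown because the read-out for compound 3 ends at a limit: the limit of > 10000 nM in this assay, at which 1 of the 3 values shown sits.

The compounds shown leave open how an open alkyl chain such as n-butyl, a benzyl group or a ring carrying an amine such as piperidinyl would read on this amide-type nitrogen. Also open, on these data alone, is whether a phenyl carrying a methoxy group or a carboxylic acid would give a lower number than the unsubstituted phenyl of compound 1.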